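Swapping Fluorophenyl for Dimethoxyphenyl on a Shared Core

The source may hold more compounds than are shown below. What is called first, only, known or untested is meant among the compounds shown, and "the series" means these compounds.

Compound 1 `N#CC1=C(N)OC(c2c[nH]c3ccccc23)=C(C#N)C1c1ccccc1` gives 26.7% in a functional assay, tested at 400 ug/mL; a lower number here means a weaker effect, a higher number a stronger effect of the compound at the concentration tested. Compound 2 `N#CC1=C(N)OC(c2c[nH]c3ccccc23)=C(C#N)C1c1ccccc1Cl` gives 21.4% in this assay, and the step of a number 5.3 percentage points lower from compound 1 to compound 2 (within the scatter) stays within the scatter. Compound 3 `N#CC1=C(N)OC(c2c[nH]c3ccccc23)=C(C#N)C1c1ccccc1F` gives "not active" (no number reported) in this assay, with no number, so no value places it among the others. Compound 4 `COc1ccc(C2C(C#N)=C(N)OC(c3c[nH]c4ccccc34)=C2C#N)cc1OC` differs from compound 3 by 3,4-dimethoxyphenyl in place of 2-fluorophenyl on a saturated ring carbon. Among the compounds with values here, none of the measured steps involves this change; the only step measured concerns a different substitution, so neither the direction nor the size of the step in this assay can be drawn from the data. Compound 4 is therefore estimated, with wide uncertainty, at 18% in this assay, between 0% and 40%.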

Compound 4, a percentage reported as activity, at one concentration (the size of the read-out at that concentration, not a potency): 28.1%
The estimate for compound 4 lay 10.1 percentage points below the measured number; measured number inside the range.
By their numbers in this assay, from the lowest: compounds 2, 1 and 4 (each within the scatter of the next).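

At this saturated ring carbon, 3,4-dimethoxyphenyl gives a number in this assay, while 2-fluorophenyl in compound 3 gives none. Measured against the other two groups, the change shows a number 1.4 percentage points higher from compound 1 to compound 4 (within the scatter) and a number 6.7 percentage points higher from compound 2 to compound 4 (within the scatter), so two methoxy groups on the phenyl ring are accepted here without a step beyond the scatter. No available data explain this result.

The steps from compound 3 cannot be read, since it has no number. On these data alone, it stays open whether an amine or a carboxylic acid on this phenyl ring would move the read-out beyond the scatter.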